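This account rests on a few compounds, and the source may have more. Where it says the series, first, only, none or still open, it means among the compounds named here.

Compound 1 `Nc1ncnc2c1ncn2[C@@H]1O[C@H](CO)[C@@H](O[C@H]2O[C@H](CO)[C@@H](OP(=O)(O)O)[C@H](OP(=O)(O)O)[C@H]2O)[C@H]1OP(=O)(O)O` gives 49% in a functional assay on the whole organism with Rattus norvegicus as the target (a higher number here means a larger maximal response, a lower number a smaller maximal response), and compound 2 `O=P(O)(O)O[C@H]1CO[C@@H]2[C@H](O)[C@@H](OP(=O)(O)O)[C@H](OP(=O)(O)O)[C@@H](O)[C@@H]2OC1` gives 59% in this assay.

Compound 2 stands at 59% in this assay, and compound 1 at 49% lies within the usual scatter of that, so the two are not told apart. Compound 3 `O=P(O)(O)O[C@@H]1CO[C@@H]2[C@H](O)[C@@H](OP(=O)(O)O)[C@H](OP(=O)(O)O)[C@@H](O)[C@@H]2OC1` keeps every atom and bond of compound 2; the change is the two compounds have the same atoms and bonds and differ only in configuration as drawn: 1 of 7 stereo elements differ; a stereocentre at a saturated ring carbon is drawn S in compound 2 and R in compound 3 and nothing else. Within the data shown here, no measured pair shows what such a change does here, so a step that stays within the scatter is expected, with no clear direction. The step of a number 4 percentage points lower from compound 2 to compound 3 (within the scatter) is expected to remain within the scatter. Compound 3 is estimated at 55%, with a range from 35% to 75% in this assay.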

Compound 3, largest response reached (reported as maximal response), in percent of the reference or control that the assay uses: 59%
Compound 3: middle estimate off by 4 percentage points, on the low side; the range from low to high includes it.
By their numbers in this assay, from the lowest: compounds 1, 2 and 3 (each within the scatter of the next).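

Inverting this one saturated ring carbon from S to R gives no change at the digits printed from compound 2 to compound 3 (within the scatter) in this assay. The earlier compounds shown here could not show this, since no two of them differed in one place, whereas here the maximal response can be read against a single stereocentre. Among these compounds, the comparison is clean at this position, but it covers only this one pair: the fact that compounds 2 and 3 differ only in the configuration as drawn. The compounds shown leave open what the other stereo elements contribute to the response. They also leave open whether a carboxylic acid in place of a phosphate group would preserve it.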